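The source may report more compounds than this note shows. Statements on the series, on what has been measured and on what is new or still open speak of the compounds shown alone.

Working notes on the series. Compound 1 `COc1ccc(-n2c(SC(C)C(=O)Nc3cc(Br)ccc3Br)nc3ccccc32)cc1` and compound 2 `COc1ccc(-n2c(SC(C)C(=O)Nc3ccc(Cl)cn3)nc3ccccc32)cc1` carry the same core. In an ADME assay on Vero cells (Chlorocebus sabaeus) for cytotoxicity, read by MTT assay, with a stated time of 24 h (a lower number here means that less compound is tolerated, a higher number that more compound is tolerated), compound 1 gives "not determined" (no result reported). In this assay compound 2 gives "not determined" (no result reported). Going by the values given here, compound 3 `CC(Sc1nc2ccccc2n1-c1ccc(F)cc1)C(=O)Nc1ncc(Cl)cc1Cl`, with a different substituent on the shared core, is the only member with a number: in this assay compound 3 gives 5900 nM. Compound 2 therefore stands nowhere on the numbers shown, and no step between measured compounds can be drawn.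

Compound 4 `COc1ccc(-n2c(SC(C)C(=O)Nc3ccc(C)cc3Cl)nc3ccccc32)cc1` differs from compound 2 in one place: 2-chloro-4-methylphenyl in place of 5-chloropyridin-2-yl on an amide-type nitrogen. Among the compounds with values here, with no measured step for this change, no direction is taken from the data; the size is unknown, and a change beyond the scatter is as plausible as none.

Compound 4 is expected to give about 6000 nM in this assay, estimated between 2000 nM and 20000 nM.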

Compound 4, half-maximal cytotoxic concentration: > 75000 nM
Compound 4 gave a limit, no number (the forecaster's own chance of this, stated with the estimate: 25%); middle value at least 12-fold (1.09 log units) away from the limit.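

No step can be read between compound 2 and compound 4, as compound 2 has no single number and compound 4 gives only a limit: the limit of > 75000 nM in this assay, at which 1 of the 4 values shown sits.

From the compounds shown here alone, whether 2-chloro-4-methylphenyl in place of 5-chloropyridin-2-yl changes the result in this assay, and by how much, stays open.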